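The source may report more compounds than this note shows. Statements on the series, on what has been measured and on what is new or still open speak of the compounds shown alone.

In an ADME assay for pharmacokinetics, read by HPLC (on this read-out higher numbers stand for a longer-lived compound and lower numbers for a shorter-lived compound), compound 1 `COCO[C@@H]1/C=C(\C)CC[C@]2([C@@](C)(O)C(=O)SCc3oc(=O)oc3C)CC(=O)N([C@H](C)c3nc(cs3)/C=C/C=C/C1=O)[S+]2[O-]` gives 24 h and compound 2 `COC1(O[C@@H]2/C=C(\C)CC[C@]3([C@@](C)(O)C(=O)SCc4oc(=O)oc4C)CC(=O)N([C@H](C)c4nc(cs4)/C=C/C=C/C2=O)[S+]3[O-])CCOCC1` gives 18 h, so these two values lie within the scatter of each other. Compound 3 `C/C1=C\[C@@H](O[C@@H]2CCCCO2)C(=O)/C=C/C=C/c2csc(n2)[C@@H](C)N2C(=O)C[C@@]([C@@](C)(O)C(=O)SCc3oc(=O)oc3C)(CC1)[S+]2[O-]` has oxan-2-yl in place of 4-methoxyoxan-4-yl on an oxygen on a saturated carbon. Within the data shown here, the only measured step that bears on this is a 1.3-fold lower number from compound 1 to compound 2 (0.12 log units; within the scatter), which involves a different group at that same place and stays within the scatter. The expected outcome in this assay is therefore a 1.1-fold higher number from compound 2 to compound 3 (0.05 log units; within the scatter), with no step beyond the scatter. Compound 3 is estimated at 20 h, with an expected range of 10 h to 38 h.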

Compound 3, half-life: 30 h
Compound 3: middle estimate off by 1.5-fold (0.18 log units), on the low side; measured number inside the range.
By their numbers in this assay, from the lowest: compounds 2, 1 and 3 (each within the scatter of the next).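

In this assay, this place on an oxygen on a saturated carbon now carries three different groups, and both new steps, a 1.7-fold higher number from compound 2 to compound 3 (0.22 log units; within the scatter) and a 1.3-fold higher number from compound 1 to compound 3 (0.10 log units; within the scatter), stay within the scatter. Oxan-2-yl, which brings a defined stereocentre, thus stands in for either 4-methoxyoxan-4-yl or methoxymethyl with no readable change in half-life. Nothing available offers an explanation for these numbers. Still open, on these data alone, is whether a free hydroxyl, an amine or a carboxylic acid at this place would give a step beyond the scatter. Also open, as far as these compounds go, is what the opposite configuration at the oxan-2-yl stereocentre would give.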